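This account rests on a few compounds, and the source may have more. Where it says the series, first, only, none or still open, it means among the compounds named here.

Compound 1 `Cc1cc(C(=O)O)nn1Cc1cc(Br)ccc1OCc1ccc(Cl)cc1` gives 8.71 nM in a functional assay on CHO-K1 cells for antagonist activity at prostaglandin E2 receptor EP1 subtype (Homo sapiens), read by FLIPR (a lower number here means a stronger inhibitor, a higher number a weaker inhibitor), the lowest of the three numbers shown, while compound 2 `Cc1cc(C(=O)O)nn1Cc1cc(Br)ccc1OCc1cccc(Cl)c1` gives 427 nM and compound 3 `Cc1cc(C(=O)O)nn1Cc1cc(Br)ccc1OCc1cc(Cl)cc(Cl)c1` gives 1120 nM. Compound 4 `Cc1cc(C(=O)O)nn1Cc1cc(Br)ccc1OCc1ccc(C(C)(C)C)cc1` differs from compound 1 by tert-butyl in place of chloro on an aromatic carbon. For the measured compounds named here, no measured step swaps that group for another kind: the steps of a 49-fold higher number from compound 1 to compound 2 (1.69 log units; beyond the scatter) and a 130-fold higher number from compound 1 to compound 3 (2.11 log units; beyond the scatter) move the chloro to a different position, and a 2.6-fold higher number from compound 2 to compound 3 (0.42 log units; beyond the scatter) adds a second chloro, so together they show only that where this ring carries its groups matters strongly. Because compound 1 gives 8.71 nM with its chloro para to a large group and compound 4 keeps a group at that place, only a modest step is expected, a 2.3-fold higher number from compound 1 to compound 4 (0.36 log units; beyond the scatter). Compound 4 is therefore estimated at 20 nM, within a range of 5 nM to 80 nM.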

Compound 4, inhibition constant: < 2000 nM
Compound 4: no number, only a limit; the forecaster's own chance of this, stated with the estimate: 2%; the middle value does not contradict the limit.
By their numbers in this assay, from the lowest: compound 1; then compound 2; then compound 3.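

In this assay compound 4 gives < 2000 nM, a limit and not a number. For the compounds shown here, no step from compound 1 to compound 4 can be read. The compounds shown leave open how far tert-butyl in place of chloro shifts the number.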